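Chain-length notes on a fluoromethoxyphenyl amide series

A few compounds are considered here, and "the series" means these few. Any claim that something is new, unique, unknown or untested is made for them only; others in the source may bear on it.

Four compounds share a fluoro- and methoxy-substituted phenyl core and differ in the amide and in the chain joining it to the ring. Compound 1 `CCC(=O)NCc1cc(OC)ccc1F` and compound 2 `CCCC(=O)NCc1ccc(F)c(OC)c1` carry a one-carbon link to the ring; compound 3 `COc1ccc(F)c(CCCNC(C)=O)c1` carries a three-carbon link. In an assay on isolated protein for agonist activity at melatonin receptor type 1C (Xenopus laevis), read by spectrophotometry (a higher number here means a larger maximal response, a lower number a smaller maximal response), compound 1 gives 69%, compound 2 gives 75%, and compound 3 gives 100%. Compound 3 stands highest of the three numbers in this assay; the nearest number, that of compound 2, lies beyond the scatter below it, and the number of compound 1 lies further below still, also beyond the scatter.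

Compound 4 `CCCC(=O)NCCCc1cc(OC)ccc1F` is the next member and has not been measured. It differs from compound 3 as follows: ethyl in place of hydrogen on a saturated chain carbon bound to a carbonyl carbon. Within the data shown here, no pair among the measured compounds isolates this change on a fixed core, so there is no direct step to lean on; compound 2, which also carries the (propylcarbonyl)amino group, gives 75% in this assay, but it differs from compound 3 in more than one place. A modest downward step is expected, at most marginally beyond the scatter, so that the step from compound 3 to compound 4 in this assay is estimated as a number 15 percentage points lower from compound 3 to compound 4 (beyond the scatter). Compound 4 is therefore expected to give about 85% in this assay, with a range from 62% to 100%.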

Compound 4, largest response reached (reported as efficacy), in percent of the reference or control that the assay uses: 100%
Compound 4: the middle estimate sits 15 percentage points below what was measured; low and high end bracket the measured number.
By their numbers in this assay, from the lowest: compounds 1 and 2 (each within the scatter of the next); then compounds 3 and 4 (each within the scatter of the next).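

Chain-length notes, continued: in this assay, the exchange of hydrogen for ethyl on a saturated chain carbon bound to a carbonyl carbon gives no change at the digits printed from compound 3 to compound 4 (within the scatter), the only direct step in the series so far. It shows that, on the core of compound 3, acetamido and (propylcarbonyl)amino cannot be told apart by maximal response, so the added ethyl, with its 2 carbon atoms, is compatible with the response seen for compound 3; this reading holds for this one core and cannot be carried over to the core of compound 1 or compound 2. No measurement at hand gives a reason for this result.

Still open, going by these compounds, is how far this position accepts other groups: a longer chain such as hexyl, a ring such as cyclopropyl, or an amine or a carboxylic acid on the same chain carbon could each behave differently from ethyl. On these data alone, the read-out gives only the largest response reached, so the concentration that compound 3 and compound 4 each need to reach that response remains open.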